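Butoxy in place of ethylamino on compound 1

The compounds below may be only part of what the source reports. "The series", "measured", "known", "first", "only" and "open" are said of these compounds alone.

Going by the values given here, in a functional assay on the whole organism for inhibition, with Mus musculus as the target (a higher number here means that more compound is needed for the effect, a lower number that less compound is needed), compound 1 `CCNC(=O)Nc1cccc2c1CN(C)CC2c1ccccc1` gives 54 mg/kg as the higher of the two numbers so far. Compound 2 `CCCCNC(=O)Nc1cccc2c1CN(C)CC2c1ccc(C)cc1` gives about 15 mg/kg. The gap between these two compounds lies beyond the scatter, with compound 2 on the lower side. Compound 3 `CCCCOC(=O)Nc1cccc2c1CN(C)CC2c1ccccc1` awaits measurement and carries butoxy in place of ethylamino on a carbonyl carbon. Among the compounds with values here, no measured pair isolates this change. Compound 2 at about 15 mg/kg also differs elsewhere, so only a small step towards a lower number, within the scatter, is expected. The expected change is a 1.7-fold lower number from compound 1 to compound 3 (0.23 log units; within the scatter) in this estimate. Compound 3 is expected at 32 mg/kg (estimated range 11 mg/kg to 90 mg/kg).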

Compound 3, dose for half-maximal effect: 2.6 mg/kg
The estimate for compound 3 lay 12-fold (1.09 log units) above the measured number, and the stated range ends above it.
By their numbers in this assay, from the lowest: compound 3; then compound 2; then compound 1.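

In this assay, butoxy in place of ethylamino on a carbonyl carbon gives a 21-fold lower number from compound 1 to compound 3 (1.32 log units; beyond the scatter), a large step and the first here that involves a change in only one place. It shows that the group on this carbonyl carbon strongly affects the dose needed for the effect. Nothing available bears on the reason for this step.

From the compounds shown here alone, the swap changes both the chain and the atom bound to the carbonyl carbon, so the contribution of each remains open. Ethoxy at this place would separate the two, while hexyloxy would show whether a longer chain goes further.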